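Removing the tert-butoxycarbonyl group from the ring amine

This account rests on a few compounds, and the source may have more. Where it says the series, first, only, none or still open, it means among the compounds named here.

Compound 1, `CN1C(=S)[C@@H](NC(=O)c2nc(Cc3ccccc3)n(C3CCN(C(=O)OC(C)(C)C)C3)n2)COc2ccccc21`, gives in a functional assay on HT-29 cells (Homo sapiens) for inhibition, read by luminescence and CellTiter-Glo, with a stated time of 24 h (a higher number here means that more compound is needed for the effect, a lower number that less compound is needed), a value that is a limit of the assay, > 10000 nM.
Compound 2, `CN1C(=S)[C@@H](NC(=O)c2nc(Cc3ccccc3)n(C3CCNC3)n2)COc2ccccc21`, gives in this assay 1070 nM.
Compound 3, `CN1C(=S)[C@@H](NC(=O)c2nc(Cc3ccccc3)n(C3CCN(C(=O)OC(C)(C)C)CC3)n2)COc2ccccc21`, gives in this assay a value that is a limit of the assay, > 10000 nM.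

Going by the values given here, the one counted change between compound 1 and compound 2 is hydrogen in place of tert-butoxycarbonyl on an amine nitrogen in a ring, and it brought an at least 9.3-fold lower number from compound 1 to compound 2 (0.97 log units; beyond the scatter). How the core of compound 3 differs from that of compound 1 is not broken down here. Among the compounds with values here, compound 4, `CN1C(=S)[C@@H](NC(=O)c2nc(Cc3ccccc3)n(C3CCNCC3)n2)COc2ccccc21`, is made from compound 3 by hydrogen in place of tert-butoxycarbonyl on an amine nitrogen in a ring; this is the same kind of change as the one from compound 1 to compound 2, but the place differs: a six-membered non-aromatic ring with three ring bonds from the ring atom that bears a large group, against a five-membered ring with two. Both measured starting points sit at the limit of > 10000 nM in this assay, at which 2 of the 3 values shown sit. Resting on the step from compound 1 to compound 2, compound 4 is expected to show an at least 6.6-fold lower number from compound 3 to compound 4 (0.82 log units; beyond the scatter). The estimate for compound 4 in this assay is 1500 nM, between 400 nM and 8000 nM.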

Compound 4, half-maximal effective concentration: 1000 nM
The estimate for compound 4 lay 1.5-fold (0.18 log units) above the measured number; the measured number falls inside the stated range.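

On the core with the six-membered ring, hydrogen in place of tert-butoxycarbonyl on an amine nitrogen in a ring brought an at least 10-fold lower number from compound 3 to compound 4 (1.00 log units; beyond the scatter) in this assay, so the change carried over in the same direction: the same change on two cores in this assay, an at least 9.3-fold lower number (0.97 log units; beyond the scatter) from compound 1 to compound 2 and an at least 10-fold lower number (1.00 log units; beyond the scatter) from compound 3 to compound 4; the limit leaves it open whether they differ. With that group gone, piperidin-4-yl in place of pyrrolidin-3-yl on the aromatic nitrogen brought a 1.1-fold lower number from compound 2 to compound 4 (0.03 log units; within the scatter), so this assay does not separate the two ring amines. What this does not show is the true size of either step, or whether the two steps are equal. The remaining step, an at least 10-fold lower number from compound 1 to compound 4 (1.00 log units; beyond the scatter), joins two changes and cannot be read as one. Compound 1 and compound 3 each give a limit of the assay, not a number: the limit of > 10000 nM in this assay, at which 2 of the 4 values shown sit.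

The compounds shown leave open whether a methyl or acetyl group on the ring nitrogen would give a number like those of compound 2 and compound 4 or a limit like that of compound 3. They also leave open how an open-chain amine in place of the ring would read in this assay.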